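The compounds below may be only part of what the source reports. "The series", "measured", "known", "first", "only" and "open" are said of these compounds alone.

Compound 1 `O=C(c1ccccc1)c1ccccc1-c1cccnc1` gives > 100000 nM in a functional assay with Rattus norvegicus as the target (on this read-out higher numbers stand for weaker inhibition and lower numbers for stronger inhibition), which is a limit of the assay rather than a number.
Compound 2 `O=C(/C=C/c1ccncc1)c1ccco1` gives 50000 nM in this assay.

Going by the values given here, of the two values shown, only that of compound 2 is a number; the other sits at the limit of > 100000 nM in this assay, at which 1 of the 2 values shown sits. Compound 2 therefore stands as the single measured point in this set, with nothing against which it can be ranked.

Compound 3 `O=C(/C=C/c1ccncc1)c1cccs1` has not yet been tested in this assay. It differs from compound 2 in one place: thiophen-2-yl in place of furan-2-yl on a carbonyl carbon. Among the compounds with values here, no pair of measured compounds here differs in a single place, so no measured step shows what such an exchange does in this assay. Both the group that leaves and the group that enters are five-membered aromatic rings with one hetero atom and one hydrogen-bond acceptor, and nothing measured speaks for a move in either direction. The step from compound 2 to compound 3 is therefore expected to stay within the usual scatter, amounting to a 1.3-fold lower number from compound 2 to compound 3 (0.10 log units; within the scatter). Compound 3 is estimated at 40000 nM, with a range from 15000 nM to 100000 nM.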

Compound 3, half-maximal inhibitory concentration: 30000 nM
For compound 3 the middle estimate is 1.3-fold (0.12 log units) above the measured one; low and high end bracket the measured number.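

In this assay the exchange of furan-2-yl for thiophen-2-yl on a carbonyl carbon comes to a 1.7-fold lower number from compound 2 to compound 3 (0.22 log units; within the scatter) and gives this set its first measured step in one place. Going by these compounds alone, at this position, then, sulfur can stand in the five-membered aromatic ring where oxygen stood with no difference that can be told from the scatter, so the two compounds read as equal on this read-out, and the earlier compounds, with no such pair among them, could not show this. Nothing measured here gives a reason for this result, and no effect can be credited to either ring or to the atom that differs between them.

What the compounds leave open is whether this position responds at all to a group of another kind, such as a phenyl ring, a pyrrol-2-yl ring or an amine on the carbonyl carbon, since a single exchange between two closely matched rings cannot show how far the number may move. Also open, as far as these compounds go, is what a longer chain in place of the double-bonded chain carbon would do to the number.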